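Ring-nitrogen substituent series: from methyl to pentan-3-yl

The compounds below may be only part of what the source reports. "The series", "measured", "known", "first", "only" and "open" are said of these compounds alone.

Compound 1 `Cn1ccnc1/C=C/C(=O)/C=C/c1coc2ccccc2c1=O` gives 2300 nM in a functional assay on LNCaP cells (Homo sapiens) for inhibition, read by WST assay, with a stated time of 3 days (a higher number here means a weaker inhibitor, a lower number a stronger inhibitor), the highest of the two numbers measured. Compound 2 `CCC(C)n1ccnc1/C=C/C(=O)/C=C/c1coc2ccccc2c1=O` gives 1300 nM in this assay. Going by the values given here, the single measured step, a 1.8-fold lower number from compound 1 to compound 2 (0.25 log units; within the scatter), bears directly on the change considered here.

Compound 3 `CCC(CC)n1ccnc1/C=C/C(=O)/C=C/c1coc2ccccc2c1=O` differs from compound 1 as follows: pentan-3-yl in place of methyl on an aromatic nitrogen. Given that the step from compound 1 to compound 2 stayed within the scatter, no step beyond the scatter is expected in this assay for compound 3, though the expected direction, a 1.6-fold lower number from compound 1 to compound 3 (0.22 log units; within the scatter), follows compound 2 because of 1300 nM. Compound 3 is therefore estimated at 1400 nM, with a range from 600 nM to 3500 nM.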

Compound 3, half-maximal inhibitory concentration: 2800 nM
Compound 3: middle estimate off by 2.0-fold (0.30 log units), on the low side, and the stated range covers the measured number.
By their numbers in this assay, from the lowest: compounds 2, 1 and 3 (each within the scatter of the next, the first and the last beyond it).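

In this assay, pentan-3-yl on the aromatic nitrogen stays level with methyl (a 1.2-fold higher number from compound 1 to compound 3 (0.09 log units; within the scatter)), so this position accepts the larger branched group without a step beyond the scatter. Going by these compounds alone, one added methyl on the saturated chain gives the only step here beyond the scatter, and a modest one (a 2.2-fold higher number from compound 2 to compound 3 (0.33 log units; beyond the scatter)). Nothing available explains that step.

Still open, from the compounds shown here alone, is whether an unbranched longer chain, a cyclopentyl group or a chain bearing an amine at this nitrogen would move the number further. Going by these compounds, the effect of a hydrogen there is also open.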